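Sulfonamide nitrogen substituent: cyclopentyl to isobutyl

This account rests on a few compounds, and the source may have more. Where it says the series, first, only, none or still open, it means among the compounds named here.

Compound 1 `CC[C@@H]1C(=O)N(C)c2cnc(Nc3ccc(S(=O)(=O)NC4CCCC4)cc3)nc2N1C1CCCC1` carries a cyclopentyl group on the sulfonamide nitrogen. In an assay for inhibition of serine/threonine-protein kinase PLK2 (Homo sapiens), read by FRET and Z'-LYTE, with a stated time of 1 h (a lower number here means a stronger inhibitor, a higher number a weaker inhibitor), compound 1 gives 23.9 nM, the lowest of the two numbers in hand. Going by the values given here, the only other measured member, compound 2 `CCCCNC(=O)c1ccc2c(ccn2-c2ncc3c(n2)N(c2ccn(C)n2)C(CC)C(=O)N3C)c1`, is built on the same core but differs in several places at once; in this assay compound 2 gives 159 nM, and the gap between the two values lies beyond the usual scatter. Among the compounds with values here, no pair of measured compounds differing in a single place has been recorded, so the effect of a single change at the sulfonamide nitrogen cannot be read from the numbers yet.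

Compound 3 `CC[C@@H]1C(=O)N(C)c2cnc(Nc3ccc(S(=O)(=O)NCC(C)C)cc3)nc2N1C1CCCC1` is the next point. It differs from compound 1 only in one place: isobutyl in place of cyclopentyl on a sulfonamide nitrogen. The group that leaves and the group that enters are of similar size and neither adds or removes donors or acceptors, so the step is expected to stay within the scatter, with at most a modest rise in the number. Compound 3 is estimated at 32 nM in this assay, with a range from 13 nM to 80 nM, which corresponds to an expected 1.3-fold higher number from compound 1 to compound 3 (0.13 log units; within the scatter).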

Compound 3, half-maximal inhibitory concentration: 21.8 nM
Beside the measured number, compound 3's estimate is 1.5-fold (0.17 log units) above it; low and high end bracket the measured number.
By their numbers in this assay, from the lowest: compounds 3 and 1 (each within the scatter of the next); then compound 2.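

In this assay the series now has its first comparison of compounds differing in one place, and it reads a 1.1-fold lower number from compound 1 to compound 3 (0.04 log units; within the scatter). At this position, on a sulfonamide nitrogen whose other neighbour is the sulfonyl sulfur, the five-membered carbon ring of cyclopentyl is therefore not needed to keep the number at the level of compound 1: the open-chain isobutyl group, with no ring, gives a value within the scatter of it. No measurement available here bears on why the two groups read alike.

Both groups in this step are made of carbon only and carry no hydrogen-bond donors or acceptors, so this single pair does not show how a 2-hydroxyethyl group, a chain ending in an amine or a carboxylic acid, or a much smaller methyl group would read on the same nitrogen. From the compounds shown here alone, the step also reaches no further than this nitrogen, so the contribution of the ethyl group and of the other cyclopentyl group on the shared core remains open.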